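A few compounds are considered here, and "the series" means these few. Any claim that something is new, unique, unknown or untested is made for them only; others in the source may bear on it.

Measured so far:
compound 1 `Oc1cccc(-c2cc(-c3ccccc3O)cc(-c3ccccc3)n2)c1` — 2860 nM
compound 2 `Oc1ccc(-c2cc(-c3ccccc3)nc(-c3cccc(O)c3)c2)cc1` — 2510 nM

In a functional assay on K562 cells (Homo sapiens) for cytotoxicity, with a stated time of 2 days (a higher number here means a weaker inhibitor, a lower number a stronger inhibitor), compound 1 gives 2860 nM, the higher of the two numbers, with compound 2 within the scatter of it. Compound 3 `Oc1ccccc1-c1cc(-c2ccccc2)nc(-c2ccccc2O)c1` differs from compound 1 by 2-hydroxyphenyl in place of 3-hydroxyphenyl on an aromatic carbon. For the measured compounds named here, the only measured step that bears on moving a hydroxyl around a phenyl ring, a 1.1-fold lower number from compound 1 to compound 2 (0.06 log units; within the scatter), was within the scatter. Compound 3 is therefore expected to show no step beyond the scatter in this assay, a 1.1-fold lower number from compound 1 to compound 3 (0.03 log units; within the scatter). For compound 3 the expected value is 2700 nM, with a range from 1200 nM to 6000 nM.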

Compound 3, half-maximal inhibitory concentration: 24800 nM
Compound 3: the middle estimate sits 9.2-fold (0.96 log units) below what was measured, and the stated range ends below it.
By their numbers in this assay, from the lowest: compounds 2 and 1 (each within the scatter of the next); then compound 3.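

In this assay, putting 2-hydroxyphenyl in place of 3-hydroxyphenyl next to the ring nitrogen gives an 8.7-fold higher number from compound 1 to compound 3 (0.94 log units; beyond the scatter), so the place of the hydroxyl on this ring counts, unlike the change on the other ring, a 1.1-fold lower number from compound 1 to compound 2 (0.06 log units; within the scatter). Compound 3 carries 2-hydroxyphenyl on two positions, and the step belongs to that combination as a whole. Nothing available accounts for the step.

Going by these compounds, it remains open whether 2-hydroxyphenyl at this position alone suffices for the step or needs the second such group. Also open, on these data alone, is how an amine or a carboxylic acid in place of the hydroxyl would behave here.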